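A piperidin-1-yl swap on compound 2

A few compounds are considered here, and "the series" means these few. Any claim that something is new, unique, unknown or untested is made for them only; others in the source may bear on it.

In a functional assay on BXPC-3 cells (Homo sapiens) for cytotoxicity, read by MTT assay, with a stated time of 72 h (on this read-out higher numbers stand for weaker inhibition and lower numbers for stronger inhibition), compound 1 (`O=C1C(Nc2cccc(-c3ccccc3)c2)=CC(=O)c2ncncc21`) gives 5100 nM and compound 2 (`CN1CCN(c2ccc(NC3=CC(=O)c4ncncc4C3=O)cc2)CC1`) gives 900 nM as the lower of the two numbers, a gap beyond the scatter. Compound 3 (`O=C1C(Nc2ccc(N3CCCCC3)cc2)=CC(=O)c2ncncc21`) has not yet been measured in this assay and carries piperidin-1-yl in place of 4-methylpiperazin-1-yl on an aromatic carbon. Among the compounds with values here, no measured pair shows this change, which leaves the size of the step open. A small rise in the number is expected, and the expected step (a 1.7-fold higher number from compound 2 to compound 3 (0.22 log units; within the scatter)) lies within the scatter. Compound 3 is estimated at 1500 nM (expected range 500 nM to 4500 nM).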

Compound 3, half-maximal inhibitory concentration: 2500 nM
Estimate against measurement, compound 3: 1.7-fold (0.22 log units) below; low and high end bracket the measured number.
By their numbers in this assay, from the lowest: compound 2; then compound 3; then compound 1.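

In this assay, exchanging 4-methylpiperazin-1-yl for piperidin-1-yl on the aromatic carbon gives a 2.8-fold higher number from compound 2 to compound 3 (0.44 log units; beyond the scatter), the first step read at this position. The two rings are therefore not interchangeable here, although the step is modest. Nothing shown explains the difference.

Going by these compounds, it remains open whether the step follows from the methyl group or from the ring nitrogen that carries it. Unsubstituted piperazin-1-yl and morpholin-4-yl at this place would separate the two.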